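The source may hold more compounds than are shown below. What is called first, only, known or untested is meant among the compounds shown, and "the series" means these compounds.

Measured so far:
compound 1 `COc1ccc(OC)c(N2C(=O)CSC2c2cccc(C(=O)NCCCCc3ccccc3)c2)c1`: 48%
compound 2 `COc1ccc(F)cc1N1C(=O)CSC1c1cccc(C(=O)NCCCCc2ccccc2)c1`: 76%
compound 3 `O=C(NCCCCc1ccccc1)c1cccc(C2SCC(=O)N2c2cccc(F)c2)c1`: 80%

In a functional assay on SJSA-1 cells (Homo sapiens) for inhibition, read by CCK-8 assay, with a stated time of 72 h, tested at 1 uM (a lower number here means less inhibition, a higher number more inhibition at the concentration tested (going by the name of the read-out)), compound 3 stands highest of the three numbers. Compound 2 lies within the scatter of it, whereas compound 1 sits well below it, as the step of a number 32 percentage points higher from compound 1 to compound 3 (beyond the scatter) shows. Compound 4 `COc1ccc(N2C(=O)CSC2c2cccc(C(=O)NCCCCc3ccccc3)c2)c(OC)c1` differs from compound 3 in one place: 2,4-dimethoxyphenyl in place of 3-fluorophenyl on an amide-type nitrogen in a ring. The step of a number 32 percentage points higher from compound 1 to compound 3 (beyond the scatter) is nearly the reverse of this change, and a number 28 percentage points higher from compound 1 to compound 2 (beyond the scatter) points the same way, while a number 4 percentage points higher from compound 2 to compound 3 (within the scatter) shows a single methoxy group making little difference. A drop beyond the scatter in this assay is therefore expected, close to the level of compound 1. Compound 4 is estimated at 50%, between 35% and 68%. This estimate means an expected step of a number 30 percentage points lower from compound 3 to compound 4 (beyond the scatter).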

Compound 4, a percentage reported as inhibition, at one concentration (the size of the read-out at that concentration, not a potency): 85%
Estimate against measurement, compound 4: 35 percentage points below; the measured number lies above the stated range.
By their numbers in this assay, from the lowest: compound 1; then compounds 2, 3 and 4 (each within the scatter of the next).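

Two methoxy groups on the amide-type nitrogen's phenyl ring do not by themselves lower the read-out in this assay: with 2,4-dimethoxyphenyl there is a number 5 percentage points higher from compound 3 to compound 4 (within the scatter) and a number 9 percentage points higher from compound 2 to compound 4 (within the scatter). The 2,5-dimethoxyphenyl group is a different matter, with a number 37 percentage points higher from compound 1 to compound 4 (beyond the scatter), so among these compounds the arrangement of the methoxy groups counts rather than their presence, and compound 1 alone stands apart. Nothing measured here explains that difference.

On these data alone, whether a phenyl ring carrying an amine or a carboxylic acid at this position would hold the same level remains open.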